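The compounds below may be only part of what the source reports. "The series", "measured", "known", "first", "only" and "open" are said of these compounds alone.

Measured compounds in a functional assay on L1210 cells (Mus musculus) for antiproliferative activity, read by cell counting, with a stated time of 2 days; on this read-out lower numbers stand for stronger inhibition and higher numbers for weaker inhibition:
Compound 1 `Cc1ccc(Nc2nc(-n3ccnc3C)cs2)cc1`: 1800 nM
Compound 2 `Cc1ccc(Nc2nc(N)c(C(=O)c3ccccc3)s2)cc1`: 2800 nM
Compound 3 `COc1cc(C(=O)c2sc(Nc3ccc(Cl)cc3)nc2N)cc(OC)c1OC`: 420 nM

Compound 2 gives the highest of these three numbers, and so the weakest inhibition shown. Its gap to compound 1 lies within the scatter, so the two cannot be told apart; its gap to compound 3 lies beyond it.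

Compound 4 `Nc1nc(Nc2ccc(Cl)cc2)sc1C(=O)c1ccccc1` is not yet measured. Compared with compound 2 it differs in one place: chloro in place of methyl on an aromatic carbon. For the measured compounds named here, no pair of measured compounds differing only in this way is available, so the size of the step is uncertain. A small step toward stronger inhibition, at the edge of the scatter, is expected, which gives a 1.6-fold lower number from compound 2 to compound 4 (0.19 log units; within the scatter). Compound 4 is estimated at 1800 nM, with a range from 600 nM to 5000 nM.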

Compound 4, half-maximal inhibitory concentration: > 10000 nM
Compound 4: only a limit was reported (the forecaster's own chance of this, stated with the estimate: 5%); middle value at least 5.5-fold (0.74 log units) away from the limit.
By their numbers in this assay, from the lowest: compound 3; then compounds 1 and 2 (each within the scatter of the next). At a limit, above all of these: compound 4.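

In this assay the change from 4-methylphenyl to 4-chlorophenyl gives an at least 3.5-fold higher number from compound 2 to compound 4 (0.55 log units; beyond the scatter) and so shows that this position matters, even for a swap of one heavy atom for another. Compound 4 gives > 10000 nM as a limit, not a number. The step therefore has a lower bound but no known upper end: the limit of > 10000 nM in this assay, at which 1 of the 4 values shown sits.

Going by these compounds, whether a fluoro or an amine at this position would track with methyl or with chloro stays open. So does whether the swap has the same size with the rest of compound 3 around it.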